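This account rests on a few compounds, and the source may have more. Where it says the series, first, only, none or still open, it means among the compounds named here.

Of the compounds shown here, two sharing one core have been tested in a functional assay on K562 cells (Homo sapiens) for cytotoxicity, read by trypan blue exclusion, with a stated time of 96 h; a lower number here means a stronger inhibitor, a higher number a weaker inhibitor. Compound 1 `COc1ccc(CS(=O)(=O)/C=C/c2c(OC)cc(O)cc2OC)cc1[N+](=O)[O-]` gives 5000 nM. Compound 2 `COC(=O)CNc1cc(CS(=O)(=O)/C=C/c2c(OC)cc(OC)cc2OC)ccc1OC` gives 100 nM, the lowest of the two numbers, and its gap to compound 1 lies beyond the usual scatter. Compound 3 `COc1cc(OC)c(/C=C/S(=O)(=O)Cc2ccc(OC)c(NC(F)(F)C(=O)O)c2)c(OC)c1` awaits measurement; it differs from compound 2 in one place: carboxy(difluoro)methyl in place of (methoxycarbonyl)methyl on a nitrogen on an aromatic ring. For the measured compounds named here, no measured pair shows this change, so its effect is unknown here. The change is expected to move the number up only moderately, a 3.0-fold higher number from compound 2 to compound 3 (0.48 log units; beyond the scatter). Compound 3 is estimated to give about 300 nM, most likely between 60 nM and 2000 nM.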

Compound 3, half-maximal inhibitory concentration: 150 nM
Beside the measured number, compound 3's estimate is 2.0-fold (0.30 log units) above it; low and high end bracket the measured number.
By their numbers in this assay, from the lowest: compounds 2 and 3 (each within the scatter of the next); then compound 1.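

In this assay, putting carboxy(difluoro)methyl in place of (methoxycarbonyl)methyl on this nitrogen gives a 1.5-fold higher number from compound 2 to compound 3 (0.18 log units; within the scatter), so this position accepts a clearly different group without a readable change in the number. Compound 1 and compound 2 differ in more than one place, so they could not show this. Nothing measured here explains the result.

This one step replaces the ester with a carboxylic acid and adds fluorine together, so neither part can be judged alone. On these data alone, the effect of a plain carboxymethyl group or a bare amine at this position stays open.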